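This account rests on a few compounds, and the source may have more. Where it says the series, first, only, none or still open, it means among the compounds named here.

Measured so far, in a functional assay on A549 cells (Homo sapiens) for antiproliferative activity, read by MTT assay; a higher number here means a weaker inhibitor, a lower number a stronger inhibitor:

- compound 1 `COc1ccc2nc(N(Cc3cc(-c4ccc(SC(F)(F)F)cc4)no3)c3nc4ccc(F)cc4s3)sc2c1` gives 26500 nM
- compound 2 `COc1ccc2nc(N(Cc3cc(-c4ccc(OC(F)(F)F)cc4)no3)c3nc4ccc(F)cc4s3)sc2c1` gives 37100 nM

Both numbers sit in the weak range. Compound 2 has no partner beyond compound 1, and the step of a 1.4-fold higher number from compound 1 to compound 2 (0.15 log units; within the scatter) is within the scatter, so the two compounds cannot be told apart on these numbers; compound 2 stands with compound 1 rather than apart from it.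

Compound 3 `COc1ccc(-c2cc(CN(c3nc4ccc(F)cc4s3)c3nc4ccc(OC)cc4s3)on2)cc1` is not yet measured. It differs from compound 2 in one place: methyl in place of trifluoromethyl on an oxygen on an aromatic ring. Cut one bond further out, this reads trifluoromethoxy to methoxy, or 4-(trifluoromethoxy)phenyl to 4-methoxyphenyl.

Among the measured compounds shown here, the only measured step touches the same position: the move from (trifluoromethyl)sulfanyl to trifluoromethoxy gave a 1.4-fold higher number from compound 1 to compound 2 (0.15 log units; within the scatter), within the scatter. For the measured compounds named here, there is no measured step for removing the fluorines from that group, so the bearing is indirect. On this basis no step beyond the scatter is expected in this assay; the estimated step is a 1.2-fold lower number from compound 2 to compound 3 (0.06 log units; within the scatter). Compound 3 is therefore expected at about 32000 nM, with a range of 12000 nM to 85000 nM.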

Compound 3, half-maximal inhibitory concentration: 38800 nM
For compound 3 the middle estimate is 1.2-fold (0.08 log units) below the measured one; measured number inside the range.
By their numbers in this assay, from the lowest: compounds 1, 2 and 3 (each within the scatter of the next).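

In this assay, methyl in place of trifluoromethyl on an oxygen on an aromatic ring gives a 1.0-fold higher number from compound 2 to compound 3 (0.02 log units; within the scatter), so taking the fluorines out of this group, a change the earlier pair did not cover, does not separate the two compounds. Methoxy in place of (trifluoromethyl)sulfanyl on an aromatic carbon gives a 1.5-fold higher number from compound 1 to compound 3 (0.17 log units; within the scatter), which places (trifluoromethyl)sulfanyl, trifluoromethoxy and methoxy together: at this place, all three compounds remain in the weak range and cannot be told apart on these numbers. No independent data are available to explain this lack of separation.

The compounds shown leave open whether a group of a different kind at this place, such as an amine or a carboxylic acid, would give a step beyond the scatter, since all three groups here attach through a sulfur or oxygen atom and carry a single carbon. They also leave open whether any change elsewhere on the shared core would move the series out of the weak range, as all three compounds differ only in this one group.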